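The compounds below may be only part of what the source reports. "The series", "measured", "known", "first", "only" and "open" are said of these compounds alone.

Among the compounds with values here, in a functional assay on FM3A cells (Mus musculus) for cytotoxicity (on this read-out lower numbers stand for an effect already at smaller amounts and higher numbers for an effect only at larger amounts of compound), compound 1 (`COOC1(OOCCCCCCI)CCCCCCCCCCC1`) gives 86000 nM and compound 2 (`CCOC(C)OOC1(OOC)CCCCCCCCCCC1`) gives 12000 nM as the lower of the two numbers so far. The next compound is compound 3 (`COOC1(OOCCC(=O)O)CCCCCCCCCCC1`), where 2-carboxyethyl stands in place of 1-ethoxyethyl on an oxygen (2-carboxyethyl in place of 1-ethoxyethyl on an oxygen). Within the data shown here, only one measured step bears on this change. It is a 7.2-fold lower number from compound 1 to compound 2 (0.86 log units; beyond the scatter) and came from 1-ethoxyethyl replacing 6-iodohexyl at that same oxygen, so swapping this group has moved the number by a modest amount. Among the measured compounds shown here, no measured compound carries 2-carboxyethyl, which leaves the direction uncertain. With compound 2 at the low end of the two numbers, a modest rise in this assay seems more likely than a further fall. For compound 3 the expected step is a 2.5-fold higher number from compound 2 to compound 3 (0.40 log units; beyond the scatter) in this estimate. Compound 3 is estimated at 30000 nM with an expected range from 8000 nM to 120000 nM in this read-out.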

Compound 3, half-maximal effective concentration: 450 nM
Estimate against measurement, compound 3: 67-fold (1.82 log units) above; the measured number lies below the stated range.
By their numbers in this assay, from the lowest: compound 3; then compound 2; then compound 1.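

In this assay the group on this oxygen can matter far more than compounds 1 and 2 alone showed: 2-carboxyethyl in place of 1-ethoxyethyl gives a 27-fold lower number from compound 2 to compound 3 (1.43 log units; beyond the scatter) as a large step where the earlier swap was only modest. Carboxy in place of 4-iodobutyl on a saturated chain carbon, two bonds along the chain from an oxygen, gives a 190-fold lower number from compound 1 to compound 3 (2.28 log units; beyond the scatter) and so places compound 3 lowest of the three, with both of its steps beyond the scatter. No measurement here explains what lies behind this drop.

Still open, from the compounds shown here alone, is whether the drop needs the carboxylic acid itself or would survive with its methyl ester or a primary amide in the same place. Going by these compounds, a longer chain ending in the same acid remains equally open.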